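This account rests on a few compounds, and the source may have more. Where it says the series, first, only, none or still open, it means among the compounds named here.

Two measured compounds share one core and differ only in the group on an aromatic carbon. Compound 1 `CCCC/C=C\c1cn([C@H]2C[C@H](O)[C@@H](CO)O2)c(=O)[nH]c1=O` carries hex-1-en-1-yl there, and in a functional assay on L1210 cells (Mus musculus) (on this read-out lower numbers stand for stronger inhibition and higher numbers for weaker inhibition), compound 1 gives 361 ug/mL. Compound 2 `O=c1[nH]c(=O)n([C@H]2C[C@H](O)[C@@H](CO)O2)cc1C#CCCCO` carries 5-hydroxypent-1-yn-1-yl instead; in this assay compound 2 gives 280 ug/mL. Going by the values given here, the only measured step, a 1.3-fold lower number from compound 1 to compound 2 (0.11 log units; within the scatter), places the number of compound 2 alongside that of compound 1, within the scatter. Among the compounds with values here, compound 3 `COCC#Cc1cn([C@H]2C[C@H](O)[C@@H](CO)O2)c(=O)[nH]c1=O` has not yet been measured. methoxy in place of 2-hydroxyethyl on a saturated chain carbon bound to a triple-bonded carbon No measured step touches the hydroxyl end of that chain, so the closest guide is the single step between compound 1 and compound 2, which swapped the whole chain and stayed within the scatter. Compound 3 is therefore expected to give about 300 ug/mL in this assay, between 110 ug/mL and 800 ug/mL. The step of a 1.1-fold higher number from compound 2 to compound 3 (0.03 log units; within the scatter) is expected to remain within the scatter.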

Compound 3, concentration for 50% inhibition: 254 ug/mL
Compound 3: the middle estimate sits 1.2-fold (0.07 log units) above what was measured, within the range that was stated.
By their numbers in this assay, from the lowest: compounds 3, 2 and 1 (each within the scatter of the next).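

Taking out the 2-hydroxyethyl in favour of methoxy on a saturated chain carbon bound to a triple-bonded carbon removes the hydrogen-bond donor of the chain, yet in this assay the result is a 1.1-fold lower number from compound 2 to compound 3 (0.04 log units; within the scatter) and nothing beyond that, so a free hydroxyl on this chain is not required for the number seen here. The wider swap of hex-1-en-1-yl for 3-methoxyprop-1-yn-1-yl on the aromatic carbon gives a 1.4-fold lower number from compound 1 to compound 3 (0.15 log units; within the scatter) and likewise does not separate the two compounds, so all three chains now read alike in this assay. No supporting data are available to explain this similarity.

Going by these compounds, whether an amine, a carboxylic acid or a longer chain on that aromatic carbon would move the number beyond the scatter remains open. So far, no change at this position has been shown to alter the read-out.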